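This account rests on a few compounds, and the source may have more. Where it says the series, first, only, none or still open, it means among the compounds named here.

Measured so far in a functional assay on A549 cells (Homo sapiens) for antiproliferative activity, read by MTT assay, with a stated time of 48 h (a higher number here means a weaker inhibitor, a lower number a stronger inhibitor), each value being a limit of the assay and not a number:
- Compound 1 `Cn1cc(C2=C(c3nn(CCCn4cccc4)c4ncccc34)C(=O)NC2=O)c2ccccc21`: > 100000 nM
- Compound 2 `Cn1cc(C2=C(c3nn(CCCn4ccnc4)c4ncccc34)C(=O)NC2=O)c2ccccc21`: > 100000 nM
- Compound 3 `Cn1cc(C2=C(c3n[nH]c4ncccc34)C(=O)NC2=O)c2ccccc21`: > 100000 nM

Compound 3 has only a limit, > 100000 nM, so no number fixes its place. The other two compounds share that limit: the limit of > 100000 nM in this assay, at which 3 of the 3 values shown sit.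

Compound 4 `Cn1cc(C2=C(c3nn(CCCN4CCCCC4)c4ncccc34)C(=O)NC2=O)c2ccccc21` carries 3-(piperidin-1-yl)propyl in place of hydrogen on an aromatic nitrogen. Its new group holds a six-membered non-aromatic ring.

The closest measured changes run the opposite way, removing a chain from that nitrogen: a step that the two limits leave unreadable from compound 1 to compound 3 and a step that the two limits leave unreadable from compound 2 to compound 3. A third change swaps the ring at the chain end: a step that the two limits leave unreadable from compound 1 to compound 2. None of these gives a size, so the expectation in this assay is loose: compound 4 may stay at the limit, and any readable number can only point towards stronger inhibition.

The expected change is an at least 1.4-fold lower number from compound 3 to compound 4 (0.15 log units; that floor lies within the scatter). For compound 4 the estimated value is 70000 nM, with an expected range of 15000 nM to 200000 nM.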

Compound 4, half-maximal inhibitory concentration: > 100000 nM
Compound 4: no number, only a limit; the forecaster's own chance of this, stated with the estimate: 55%; middle value at least 1.4-fold (0.15 log units) away from the limit.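

In this assay compound 4 gives only a limit, > 100000 nM. Its steps from compound 1, compound 2 and compound 3 cannot be read, because all four share that limit: the limit of > 100000 nM in this assay, at which 4 of the 4 values shown sit.

The compounds shown leave open whether any chain on that aromatic nitrogen changes inhibition at all.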